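The source may report more compounds than this note shows. Statements on the series, on what has been measured and on what is new or still open speak of the compounds shown alone.

In a functional assay on HGC-27 cells (Homo sapiens) for inhibition, read by MTT assay, with a stated time of 72 h (a lower number here means a stronger inhibitor, a higher number a weaker inhibitor), compound 1, whose structure is `Cc1cc(N2CC[C@@H](C)[C@@H](N(C)c3ncnc4[nH]ccc34)C2)n2nc(SCc3ccc(F)cc3)nc2n1`, gives 26000 nM. Going by the values given here, this is the only number so far in this assay. Among the compounds with values here, compound 2, with the structure `CCc1cc(N2CC[C@@H](C)[C@@H](N(C)c3ncnc4[nH]ccc34)C2)n2ncnc2n1`, returns only a limit of the assay, reading > 100000 nM in this assay; with a limit on one side, compound 1 cannot be ranked against it in any direction, and no single-place step between measured compounds is available, so the record holds only (the limit of > 100000 nM in this assay, at which 1 of the 2 values shown sits).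

Compound 3, whose structure is `Cc1cc(N2CC[C@@H](C)[C@@H](N(C)c3ncnc4[nH]ccc34)C2)n2nc(SCc3ccc([N+](=O)[O-])cc3)nc2n1`, differs from compound 1 by nitro in place of fluoro on an aromatic carbon. Nothing in the measured pairs bears on how a nitro in place of fluoro on an aromatic carbon shifts this assay, so the step is expected to be small, in either direction or none beyond the scatter, and compound 3 is estimated at 26000 nM, with a range from 8000 nM to 85000 nM, which corresponds to an expected step of no change at the digits printed from compound 1 to compound 3 (within the scatter).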

Compound 3, half-maximal inhibitory concentration: 29400 nM
The estimate for compound 3 lay 1.1-fold (0.05 log units) below the measured number; the range from low to high includes it.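

In this assay, the change from (4-fluorobenzyl)sulfanyl to (4-nitrobenzyl)sulfanyl comes with a 1.1-fold higher number from compound 1 to compound 3 (0.05 log units; within the scatter). Going by these compounds alone, this is the first single-place step, and it shows that on this aromatic carbon, para to a large group, nitro with its 2 hydrogen-bond acceptors can replace fluoro, which has none, without moving the reading beyond the scatter. Nothing measured here accounts for this result.

On these data alone, whether an amine, a carboxylic acid or a methoxy group on the same carbon would also leave the reading within the scatter remains open. Compound 2 lacks the whole side chain but also differs from compound 1 in another place and gives only a limit of the assay, so the part played by the side chain itself remains unread: the limit of > 100000 nM in this assay, at which 1 of the 3 values shown sits.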